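Shrinking the ring on the amine nitrogen

The compounds below may be only part of what the source reports. "The series", "measured", "known", "first", "only" and "open" are said of these compounds alone.

Of the compounds shown here, three sharing one core have been tested. Compound 3 `c1ccc(COc2ccc(OCCOCCNC3CCCCC3)cc2)cc1` gives the lowest number of the three in a functional assay on SK-OV-3 cells (Homo sapiens) for inhibition, read by CCK-8 assay, with a stated time of 70 h (a higher number here means a weaker inhibitor, a lower number a stronger inhibitor), at 7370 nM. Compound 1 `c1ccc(COc2ccc(OCCOCCNc3ccncc3)cc2)cc1` gives 20600 nM, and compound 2 `c1ccc(COc2ccc(OCCOCCNC3CCOC3)cc2)cc1` gives 48000 nM. Compound 4 `c1ccc(COc2ccc(OCCOCCNC3CCC3)cc2)cc1` is the next step: cyclobutyl in place of cyclohexyl on an amine nitrogen. The closest comparison is a 6.5-fold lower number from compound 2 to compound 3 (0.81 log units; beyond the scatter), where the six-membered carbon ring outdid a five-membered ring holding an oxygen; a 2.8-fold lower number from compound 1 to compound 3 (0.45 log units; beyond the scatter) points the same way. Within the data shown here, no measured step exchanges two carbon rings of different size, so the smaller cyclobutyl is expected to give a modestly higher number, roughly a 2.0-fold higher number from compound 3 to compound 4 (0.31 log units; beyond the scatter). Compound 4 is therefore estimated at 15000 nM, within a range of 6000 nM to 40000 nM.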

Compound 4, half-maximal inhibitory concentration: 25000 nM
Compound 4: middle estimate off by 1.7-fold (0.22 log units), on the low side, and the stated range covers the measured number.
By their numbers in this assay, from the lowest: compound 3; then compounds 1, 4 and 2 (each within the scatter of the next, the first and the last beyond it).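

Going from cyclohexyl to cyclobutyl on the amine nitrogen weakens inhibition in this assay (with a 3.4-fold higher number from compound 3 to compound 4 (0.53 log units; beyond the scatter)), so the size of a ring made only of carbon matters at this position, which no earlier pair could show. Cyclobutyl does not stand apart from the other two rings (with a 1.9-fold lower number from compound 2 to compound 4 (0.28 log units; within the scatter) and a 1.2-fold higher number from compound 1 to compound 4 (0.08 log units; within the scatter)), as both steps lie within the scatter. Nothing measured here explains the change. As far as these compounds go, whether cyclopentyl would fall between cyclobutyl and cyclohexyl, and whether a larger ring such as cycloheptyl would lower the number further, stays open.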